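Adding a Methyl to the Amine Nitrogen of Compound 2

A few compounds are considered here, and "the series" means these few. Any claim that something is new, unique, unknown or untested is made for them only; others in the source may bear on it.

In a physicochemical assay for acid dissociation, compound 1 `Cn1cc(-c2noc(CN)n2)c2ccccc21` gives 6.4 and compound 2 `CNCc1nc(-c2cn(C)c3ccccc23)no1` gives 6.5 on this scale, so the two lie within the scatter of each other and compound 2 holds no separate place from compound 1. Within the data shown here, the one measured step between them is a number 0.10 log units higher from compound 1 to compound 2 (within the scatter) and consists of methyl in place of hydrogen on an amine nitrogen.

Compound 3 `CN(C)Cc1nc(-c2cn(C)c3ccccc23)no1` carries the same kind of change once more. Here methyl in place of hydrogen on an amine nitrogen is again methyl in place of hydrogen on an amine nitrogen, turning (methylamino)methyl into (dimethylamino)methyl.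

Among the measured compounds shown here, only that single step from compound 1 bears on this change, and one step is thin support. No shift beyond the scatter is therefore expected in this assay in either direction. The estimated step is a number 0.20 log units lower from compound 2 to compound 3 (within the scatter) and remains an expectation until it is measured. For the measured compounds named here, only two compounds have numbers so far, so the range is kept wide. For compound 3 the estimate is 6.3 with an expected range from 5.8 to 6.7 for the measurement still to come.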

Compound 3, acid dissociation constant: 5.6
Beside the measured number, compound 3's estimate is 0.70 log units above it, outside the stated range (below it).
By their numbers in this assay, from the lowest: compound 3; then compounds 1 and 2 (each within the scatter of the next).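

The same replacement of hydrogen by methyl on an amine nitrogen does not carry the same size at each stage in this assay: a number 0.10 log units higher from compound 1 to compound 2 (within the scatter) stands against a number 0.90 log units lower from compound 2 to compound 3 (beyond the scatter) for the stage at the nitrogen whose other neighbours are both saturated chain carbons. Read as a single change, dimethylamino in place of amino on a saturated chain carbon bound to an aromatic carbon gives a number 0.80 log units lower from compound 1 to compound 3 (beyond the scatter) and so also places compound 3 apart, which shows that at this position the effect of methyl depends on what the nitrogen already carries, and that the step from amino to methylamino gave no guide to the next one. Nothing available here accounts for this difference between the two stages.

The compounds shown leave open whether the shift belongs to dimethylamino in particular or would also appear with an ethyl group on this nitrogen, or with the nitrogen closed into a pyrrolidine ring. They also leave open how a longer chain between the amine and the core would read on this scale.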